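The compounds below may be only part of what the source reports. "The series", "measured", "known", "first", "only" and "open" are said of these compounds alone.

Measured compounds:
Compound 1 `Nc1nn(C(=O)Nc2ccc(Cc3ccccc3)cc2)c2ccccc12` gives 83500 nM in a functional assay on NCI-H23 cells (Homo sapiens) for antiproliferative activity, read by sulforhodamine B assay, with a stated time of 48 h; on this read-out lower numbers stand for stronger inhibition of growth and higher numbers for weaker inhibition of growth.
Compound 2 `Nc1nn(C(=O)Nc2ccc(Cc3ccccc3)cc2)c2ccc(Cl)cc12` gives 68400 nM in this assay.

Compound 2 stands with the lowest of the two numbers, but its nearest neighbour is compound 1, and the step of a 1.2-fold lower number from compound 1 to compound 2 (0.09 log units; within the scatter) lies within the scatter, so the two cannot be ordered.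

Compound 3 `Nc1ccc2c(c1)c(N)nn2C(=O)Nc1ccc(Cc2ccccc2)cc1` is the next member. Against compound 2 the change is amino in place of chloro on an aromatic carbon — in words, amino in place of chloro on an aromatic carbon.

Among the compounds with values here, only one measured step bears on this position, the one from compound 1 to compound 2, which was a 1.2-fold lower number from compound 1 to compound 2 (0.09 log units; within the scatter): swapping hydrogen for chloro there changed nothing beyond the scatter. Within the data shown here, no measured compound carries an amino at this place, so there is no direct precedent for the group that enters. On that basis the step from compound 2 to compound 3 in this assay is expected to be small, a 1.1-fold higher number from compound 2 to compound 3 (0.04 log units; within the scatter), with no direction that can be called beyond the scatter.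

Compound 3 is therefore estimated at 75000 nM, with a range from 35000 nM to 160000 nM.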

Compound 3, concentration for total growth inhibition: 39500 nM
For compound 3 the middle estimate is 1.9-fold (0.28 log units) above the measured one; low and high end bracket the measured number.
By their numbers in this assay, from the lowest: compounds 3, 2 and 1 (each within the scatter of the next, the first and the last beyond it).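

In this assay, within the data shown here, amino in place of hydrogen on this aromatic carbon gives the first step at this position that passes the scatter, though only modestly (a 2.1-fold lower number from compound 1 to compound 3 (0.33 log units; beyond the scatter)). Chloro in place of hydrogen at the same place stayed within the scatter (a 1.2-fold lower number from compound 1 to compound 2 (0.09 log units; within the scatter)), and amino in place of chloro does too (a 1.7-fold lower number from compound 2 to compound 3 (0.24 log units; within the scatter)), so the amino and chloro compounds cannot be ordered and only the amino compound separates from the hydrogen parent. No measured evidence accompanies these three compounds to account for this small separation.

Going by these compounds, it remains open whether other nitrogen-bearing groups at this place, such as dimethylamino or acetamido, or oxygen-bearing ones, such as hydroxyl or methoxy, would extend the step seen with amino in this assay or fall back within the scatter of the hydrogen parent. On these data alone, it is also open whether the step from hydrogen to amino would hold with another group at a different place on the shared core, or with the amino moved to another aromatic carbon of the same ring.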